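Benzyloxypyridinone series: cyclopropyl to ethyl on the bicyclic core

The source may report more compounds than this note shows. Statements on the series, on what has been measured and on what is new or still open speak of the compounds shown alone.

Measured so far:
compound 1 `Cc1c(C2CC2)nc2ccc(-n3ccc(OCc4ccccc4)cc3=O)cn12` — 42 nM
compound 2 `Cc1c(C2CC2)nc2ccc(-n3ccc(OCc4ccc(Br)cc4)cc3=O)cn12` — 12 nM

In an assay on CHO cells for displacement of a labelled ligand from melanin-concentrating hormone receptor 1 (Homo sapiens), read by scintillation counting, with a stated time of 1 h (on this read-out higher numbers stand for weaker inhibition and lower numbers for stronger inhibition), compound 1 gives 42 nM, the higher of the two numbers recorded. Its nearest neighbour is compound 2, reached by bromo in place of hydrogen on an aromatic carbon of the benzyl ring: a 3.5-fold lower number from compound 1 to compound 2 (0.54 log units; beyond the scatter).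

Compound 3 `CCc1nc2ccc(-n3ccc(OCc4ccccc4)cc3=O)cn2c1C` is not yet measured. It differs from compound 1 by ethyl in place of cyclopropyl on an aromatic carbon. Among the compounds with values here, no measured pair changes this group: the single recorded step concerns the benzyl ring, far from the altered position, and it offers no direct guide to the effect of a smaller substituent on the fused core. The change is small and keeps the rest of the molecule intact. In this assay the step from compound 1 to compound 3 is therefore expected to stay within the usual scatter, with a slight lean toward a higher number: a 1.4-fold higher number from compound 1 to compound 3 (0.15 log units; within the scatter). Compound 3 is thus estimated at 60 nM, with a plausible range from 20 nM to 180 nM.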

Compound 3, half-maximal inhibitory concentration: 120 nM
Estimate against measurement, compound 3: 2.0-fold (0.30 log units) below; measured number inside the range.
By their numbers in this assay, from the lowest: compound 2; then compound 1; then compound 3.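

In this assay, within the data shown here, the swap of cyclopropyl for ethyl on this aromatic carbon of the shared core gives a 2.9-fold higher number from compound 1 to compound 3 (0.46 log units; beyond the scatter) and this is the first read on the position, as the earlier step concerned only the benzyl ring. The position is therefore not indifferent to a small change: a three-membered ring of carbon leaves, an open ethyl chain with one heavy atom fewer enters, and the number moves beyond the scatter, with the cyclopropyl compound the lower of the pair. No measurement on hand explains this step.

The single pair changes ring and heavy-atom count together, so the compounds shown leave open which of the two goes with the step; isopropyl or cyclobutyl on this same carbon would bear on that question. Also open, going by these compounds, is whether bromo on the benzyl ring, which lowers the number on the cyclopropyl compound, does the same when ethyl stands on the core.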